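Aryl ether to aryl thioether on the shared core

This account rests on a few compounds, and the source may have more. Where it says the series, first, only, none or still open, it means among the compounds named here.

The series shares the core of compound 1 `Nc1cc(N)c2nc(-c3ccccc3)c(Oc3ccc(Cl)c(Cl)c3)nc2c1`, which in a functional assay on MDA-MB-435 cells (Homo sapiens) for inhibition, read by sulforhodamine B assay, with a stated time of 48 h (a higher number here means a weaker inhibitor of growth, a lower number a stronger inhibitor of growth), gives 20900 nM. Compound 2 `CCOC(=O)[C@H](CCC(=O)O)NC(=O)c1ccc(Oc2nc3cc(N)cc(N)c3nc2-c2ccccc2)cc1` in this assay gives only a limit, < 100000 nM, and not a number. Compound 1 therefore holds the only number shown; the other value recorded is the limit of < 100000 nM in this assay, at which 1 of the 2 values shown sits. Among the compounds with values here, no pair of measured compounds differing in one place is available, so no measured step exists to calibrate the change below.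

Compound 3 `Nc1cc(N)c2nc(-c3ccccc3)c(Sc3ccc(F)cc3)nc2c1` carries (4-fluorophenyl)sulfanyl in place of 3,4-dichlorophenoxy on an aromatic carbon, that is, (4-fluorophenyl)sulfanyl in place of 3,4-dichlorophenoxy on an aromatic carbon. With nothing measured to lean on, the expectation is a step of a 1.2-fold higher number from compound 1 to compound 3 (0.08 log units; within the scatter), no larger than the usual scatter and of uncertain direction. In this assay compound 3 is estimated at 25000 nM, with a range from 7000 nM to 90000 nM.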

Compound 3, concentration for total growth inhibition: 33100 nM
Compound 3: the middle estimate sits 1.3-fold (0.12 log units) below what was measured; measured number inside the range.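

In this assay, (4-fluorophenyl)sulfanyl in place of 3,4-dichlorophenoxy on this aromatic carbon gives a 1.6-fold higher number from compound 1 to compound 3 (0.20 log units; within the scatter), so the position takes this exchange with no step beyond the scatter. Within the data shown here, this is the first measured step on the series, but it joins two differences in one: the oxygen link gives way to a sulfur link, and the two chlorines on the ring give way to a single fluorine, so the step cannot be divided between them. Nothing measured here accounts for the step.

Still open, on these data alone, is how a 3,4-dichlorophenylsulfanyl group would read at this carbon, which would separate the link from the ring substituents. Also open, as far as these compounds go, is whether a saturated amine such as piperidine or a longer alkyl chain at this carbon would move the number beyond the scatter.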